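A few compounds are considered here, and "the series" means these few. Any claim that something is new, unique, unknown or untested is made for them only; others in the source may bear on it.

Measured compounds in an assay on HEK293 cells for inhibition of Lysophosphatidylserine lipase ABHD12 (Homo sapiens), read by scintillation counting, with stated times of 30 min and 5 min; on this read-out higher numbers stand for weaker inhibition and lower numbers for stronger inhibition:
Compound 1 `Cc1ccc(C(=O)NC2CCCCCC2)c(=O)n1Cc1ccc(F)cc1`: > 10000 nM, a limit of the assay.
Compound 2 `Cc1c(-c2ccc(F)cc2)cc(C(=O)NC2CCCCCC2)c(=O)n1Cc1ccc(F)cc1`: 600 nM.
Compound 3 `Cc1ccc(C(=O)NC2CCCCCC2)c(OCc2ccc(F)cc2)n1`: > 10000 nM, again a limit.

Compound 1 therefore has no number of its own in this assay; its result is only a limit, and the same is true of compound 3, so on the numbers shown compound 1 stands at the weak end, with compound 2 the only compound that gives an actual value.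

Compound 4 `Cc1c(-c2ccccc2)cc(C(=O)NC2CCCCCC2)c(=O)n1Cc1ccc(F)cc1` differs from compound 1 in one place: phenyl in place of hydrogen on an aromatic carbon. Among the compounds with values here, the only measured step that bears on this is the one in which a 4-fluorophenyl group enters at the same position, an at least 16-fold lower number from compound 1 to compound 2 (1.22 log units; beyond the scatter), a large step that can only be given as a lower bound because the starting point sits at the limit of > 10000 nM in this assay, at which 2 of the 3 values shown sit. A plain phenyl group entering at the same place is expected to act much like the 4-fluorophenyl group, so a step of comparable size is expected, an at least 11-fold lower number from compound 1 to compound 4 (1.04 log units; beyond the scatter).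

For compound 4 the estimated value in this assay is 900 nM, with a range from 300 nM to 3000 nM.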

Compound 4, half-maximal inhibitory concentration: > 10000 nM
Compound 4 gave a limit, no number (the forecaster's own chance of this, stated with the estimate: 10%); middle value at least 11-fold (1.04 log units) away from the limit.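

In this assay, the fluoro atom on the added ring proves decisive at this position: hydrogen in its place gives an at least 16-fold higher number from compound 2 to compound 4 (1.22 log units; beyond the scatter). The gain seen earlier on this aromatic carbon therefore does not come from a six-membered aromatic ring alone, since a plain phenyl group there does not bring a readable number. The step from hydrogen to phenyl itself cannot be read, since both of its ends are limits: the limit of > 10000 nM in this assay, at which 3 of the 4 values shown sit.

What the compounds shown leave open is whether only fluoro does this, or whether a chloro, methyl or methoxy group in its place on the phenyl ring would also give a readable number. As far as these compounds go, how far compound 4 falls short of compound 2 also remains open, as its result is a limit and not a number.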